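Three Anilides Level in Clearance, a Bromofluoro Case Next

The source may report more compounds than this note shows. Statements on the series, on what has been measured and on what is new or still open speak of the compounds shown alone.

Measured so far in an in vitro ADME assay on microsomes from liver (Homo sapiens) for pharmacokinetics, read by LC-MS, with a stated time of 10 min, tested at 1 uM; on this read-out lower numbers stand for slow clearance and higher numbers for fast clearance:
compound 1 `CC(C)c1ccc(NC(=O)[C@H]2CN(C)C[C@@H]2c2ccc(/C=C/C(=O)Nc3ccccc3N)cc2)cc1` at 10 mL/min/kg
compound 2 `CN1C[C@H](C(=O)Nc2cccc(F)c2)[C@@H](c2ccc(/C=C/C(=O)Nc3ccccc3N)cc2)C1` at 6 mL/min/kg
compound 3 `CN1C[C@H](C(=O)Nc2ccccc2F)[C@@H](c2ccc(/C=C/C(=O)Nc3ccccc3N)cc2)C1` at 10 mL/min/kg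

All three values lie within the scatter of one another. Compound 3 stands level with compound 1, as no change at the digits printed from compound 1 to compound 3 (within the scatter) shows, and a 1.7-fold higher number from compound 2 to compound 3 (0.22 log units; within the scatter) stays small as well.

Compound 4 `CN1C[C@H](C(=O)Nc2ccc(F)c(Br)c2)[C@@H](c2ccc(/C=C/C(=O)Nc3ccccc3N)cc2)C1` carries one change from compound 3: 3-bromo-4-fluorophenyl in place of 2-fluorophenyl on an amide-type nitrogen. This places 3-bromo-4-fluorophenyl in place of 2-fluorophenyl on an amide-type nitrogen. The measured steps that bear on it are changes at that same nitrogen, and they are a 1.7-fold lower number from compound 1 to compound 2 (0.22 log units; within the scatter), no change at the digits printed from compound 1 to compound 3 (within the scatter) and a 1.7-fold higher number from compound 2 to compound 3 (0.22 log units; within the scatter). None leaves the scatter, even with 4-isopropylphenyl in compound 1. Going by the values given here, no measured compound carries bromine, so this reasoning remains an extrapolation. The expected size of the change is no change at the digits printed from compound 3 to compound 4 (within the scatter), which means no step beyond the scatter in this assay is anticipated. Compound 4 is estimated at 10 mL/min/kg, with an expected range from 5 mL/min/kg to 20 mL/min/kg.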

Compound 4, clearance: 15 mL/min/kg
Beside the measured number, compound 4's estimate is 1.5-fold (0.18 log units) below it; low and high end bracket the measured number.
By their numbers in this assay, from the lowest: compounds 2, 1, 3 and 4 (each within the scatter of the next, the first and the last beyond it).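

In this assay, going by these compounds alone, 3-bromo-4-fluorophenyl on the amide-type nitrogen gives the first step at this position that leaves the scatter, and that modest step is a 2.5-fold higher number from compound 2 to compound 4 (0.40 log units; beyond the scatter). Against the other two groups the new one stays within the scatter, with a 1.5-fold higher number from compound 3 to compound 4 (0.18 log units; within the scatter) and a 1.5-fold higher number from compound 1 to compound 4 (0.18 log units; within the scatter), so it stands apart only from 3-fluorophenyl and not from 2-fluorophenyl or 4-isopropylphenyl. Within the data shown here, nothing available here explains the one step beyond the scatter.

The compounds shown leave open whether that step goes with the bromine or with the fluorine of the new group, since the two always enter together here. They also leave open how this clearance would read with an amine, a carboxylic acid or a pyridine ring at the same nitrogen.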